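Removing a methoxy from the weakest of three chalcone-pyrazole analogues

The compounds below may be only part of what the source reports. "The series", "measured", "known", "first", "only" and "open" are said of these compounds alone.

Of the compounds shown here, three have been measured in a functional assay on A549 cells (Homo sapiens) for cytotoxicity, read by sulforhodamine B assay, with a stated time of 48 h, tested at 10 uM; on this read-out higher numbers stand for a weaker effect at the one concentration tested and lower numbers for a stronger effect. Compound 1 `COc1ccc(C(=O)/C=C/c2cc(-c3cc(OC)c(OC)c(OC)c3)n[nH]2)cc1OC` gives -43%, compound 2 `COc1ccc(C(=O)/C=C/c2cc(-c3cc(OC)c(OC)c(OC)c3)n[nH]2)cc1` gives -15%, and compound 3 `COc1cc(C(=O)/C=C/c2cc(-c3cc(OC)c(OC)c(OC)c3)n[nH]2)cc(OC)c1OC` gives 6%. Compound 3 therefore stands highest, that is weakest, of the three: the gap to compound 2 and the gap to compound 1 both lie beyond the scatter.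

Compound 4 `COc1ccc(-c2cc(/C=C/C(=O)c3cc(OC)c(OC)c(OC)c3)[nH]n2)cc1OC` is the next step. hydrogen in place of methoxy on an aromatic carbon

Among the measured compounds shown here, two measured steps concern a methoxy group on an aromatic carbon. Taking one away gave a number 28 percentage points higher from compound 1 to compound 2 (beyond the scatter), while adding one gave a number 49 percentage points higher from compound 1 to compound 3 (beyond the scatter). Both steps weakened the effect, yet they point in opposite structural directions, and both took place on the other six-membered aromatic ring of carbon only, so neither maps directly onto the change from compound 3 to compound 4. A modest step is therefore expected, with its direction uncertain, so a number 11 percentage points lower from compound 3 to compound 4 (beyond the scatter) is the estimate. Compound 4 is expected to give -5%, within the range -35% to 25%.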

Compound 4, a percentage reported as activity, at one concentration (the size of the read-out at that concentration, not a potency): -2%
The estimate for compound 4 lay 3 percentage points below the measured number; measured number inside the range.
By their numbers in this assay, from the lowest: compound 1; then compound 2; then compounds 4 and 3 (each within the scatter of the next).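

In this assay, putting hydrogen in place of this methoxy leaves the read-out within the scatter: a number 8 percentage points lower from compound 3 to compound 4 (within the scatter). On the core of compound 3, then, this methoxy, which sits ortho to a methoxy group and meta to a large group, can be replaced by hydrogen without a change that can be told apart from the usual spread of repeated measurements. Taking a methoxy away does not give the same result on both cores, and the gap between the two steps is itself larger than the scatter: the same change on two cores in this assay, a number 28 percentage points higher (beyond the scatter) from compound 1 to compound 2 and a number 8 percentage points lower (within the scatter) from compound 3 to compound 4, 36 percentage points apart, beyond the scatter of two such steps.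

As far as these compounds go, whether an amine, a hydroxy group or a carboxylic acid on this carbon would shift the number remains open, as does the effect of removing the other methoxy groups on this ring. A reading at one concentration also gives no potency for any of these compounds.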